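Urea terminus variation on the sulfonamide series

The source may hold more compounds than are shown below. What is called first, only, known or untested is meant among the compounds shown, and "the series" means these compounds.

Compound 1 `CNC(=O)Nc1ccc(S(=O)(=O)Nc2cccc(-c3nc(-c4ccc(NC(=O)c5cccnc5)cc4Cl)no3)c2)cc1`: 1300 nM
Compound 2 `CCN(CC)C(=O)Nc1ccc(S(=O)(=O)Nc2cccc(-c3nc(-c4ccc(NC(=O)c5cccnc5)cc4Cl)no3)c2)cc1`: 8700 nM

Going by the values given here, in a functional assay on MDA-MB-231 cells (Homo sapiens) for antiproliferative activity, read by MTT assay, with a stated time of 72 h (on this read-out lower numbers stand for stronger inhibition and higher numbers for weaker inhibition), compound 2 stands at the higher of the two measured numbers; the one measured step, a 6.7-fold higher number from compound 1 to compound 2 (0.83 log units; beyond the scatter), separates it from compound 1. Compound 3 `O=C(Nc1ccc(-c2noc(-c3cccc(NS(=O)(=O)c4ccc(NC(=O)N5CCCCC5)cc4)c3)n2)c(Cl)c1)c1cccnc1` differs by piperidin-1-yl in place of diethylamino on a carbonyl carbon. Among the compounds with values here, no measured step covers this exchange directly. Both diethylamino and piperidin-1-yl carry no hydrogen-bond donors, so compound 3 is expected to stay close to compound 2, and the expected step of a 1.3-fold lower number from compound 2 to compound 3 (0.13 log units; within the scatter) lies within the scatter. Compound 3 is estimated at 6500 nM, with a range from 2200 nM to 20000 nM.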

Compound 3, half-maximal inhibitory concentration: > 10000 nM
Compound 3: only a limit was reported (the forecaster's own chance of this, stated with the estimate: 5%); middle value at least 1.5-fold (0.18 log units) from the limit.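

In this assay compound 3 gives a limit and not a number: the limit of > 10000 nM in this assay, at which 1 of the 3 values shown sits. Piperidin-1-yl in place of diethylamino gives an at least 1.1-fold higher number from compound 2 to compound 3 (0.06 log units; that floor lies within the scatter), so this floor does not separate the two compounds. Against methylamino the step is clear, an at least 7.6-fold higher number from compound 1 to compound 3 (0.88 log units; beyond the scatter), so diethylamino and piperidin-1-yl on this carbonyl carbon both give higher numbers than methylamino.

Open, on these data alone, is where an unsubstituted amino group, a dimethylamino group or a morpholin-4-yl group on this carbonyl carbon would stand relative to compound 1. With compound 3 held at a limit, the true distance between compound 2 and compound 3 also stays unresolved.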